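Swapping the Hydrazone Aryl Arm: What Compound 3 May Give

This account rests on a few compounds, and the source may have more. Where it says the series, first, only, none or still open, it means among the compounds named here.

Two compounds have been measured in a functional assay on NCI-H460 cells (Homo sapiens) for inhibition, read by sulforhodamine B assay, with a stated time of 48 h; a lower number here means a stronger inhibitor of growth, a higher number a weaker inhibitor of growth:

Compound 1 `NS(=O)(=O)c1ccc(Nc2nc(N/N=C/c3ccc(C(F)(F)F)cc3)nc(Nc3ccccc3)n2)cc1` gives 3020 nM.
Compound 2 `Cc1nn(-c2ccccc2)cc1/C=N/Nc1nc(Nc2ccccc2)nc(Nc2ccc(S(N)(=O)=O)cc2)n1` gives 2770 nM.

Both share the same core, with a sulfonamide-bearing aniline on one side and a plain aniline on the other; they differ only in the aryl group hanging from the carbon with a double bond to nitrogen. Compound 2 stands alongside compound 1 rather than apart from it: the step of a 1.1-fold lower number from compound 1 to compound 2 (0.04 log units; within the scatter) lies within the scatter, so the two cannot be told apart on these numbers.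

Compound 3 `NS(=O)(=O)c1ccc(Nc2nc(N/N=C/c3ccccn3)nc(Nc3ccccc3)n2)cc1` differs from compound 2 by pyridin-2-yl in place of 3-methyl-1-phenyl-1H-pyrazol-4-yl on a carbon with a double bond to nitrogen. Within the data shown here, the only measured step that touches this same position is a 1.1-fold lower number from compound 1 to compound 2 (0.04 log units; within the scatter), where one aryl group was exchanged for a quite different one and the number did not move beyond the scatter. On that single precedent, the exchange for a pyridin-2-yl group is expected to produce a step of a 1.1-fold higher number from compound 2 to compound 3 (0.03 log units; within the scatter) with no size beyond the scatter. Compound 3 is therefore estimated at 3000 nM, with a range from 1000 nM to 9000 nM.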

Compound 3, concentration for 50% growth inhibition: 2410 nM
Estimate against measurement, compound 3: 1.2-fold (0.10 log units) above, and the stated range covers the measured number.
By their numbers in this assay, from the lowest: compounds 3, 2 and 1 (each within the scatter of the next).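

Compound 3 tests something the first pair did not: whether this position needs a group of the size found in compound 2. In this assay, pyridin-2-yl, a single ring with 6 heavy atoms, replaces the two-ring 3-methyl-1-phenyl-1H-pyrazol-4-yl with 12 heavy atoms, and the result is a 1.1-fold lower number from compound 2 to compound 3 (0.06 log units; within the scatter), so this large cut in size leaves no change that can be read. The comparison with the 4-(trifluoromethyl)phenyl group gives a 1.3-fold lower number from compound 1 to compound 3 (0.10 log units; within the scatter), so all three aryl groups on the carbon with a double bond to nitrogen sit level, and no measurement at hand explains why.

All three compounds carry an aromatic ring at this position, so they leave open whether the flat level holds for a non-aromatic group such as a cyclohexyl ring or a butyl chain, or for a ring bearing a carboxylic acid or an amine. Going by these compounds, they also keep the sulfonamide-bearing aniline and the plain aniline throughout, so how far the number depends on those two arms remains unknown.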